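The source may report more compounds than this note shows. Statements on the series, on what has been measured and on what is new or still open speak of the compounds shown alone.

Compound 1 `O=C(/C=C/c1ccc(O)c(O)c1)CC(=O)/C=C/c1cccc(O)c1O`: 16000 nM
Compound 2 `O=C(/C=C/c1cccc(O)c1O)CC(=O)/C=C/c1cccc(O)c1O`: 39000 nM
Compound 3 `O=C(/C=C/c1cc(O)ccc1O)CC(=O)/C=C/c1cccc(O)c1O`: 53000 nM

These values come from an ADME assay on PC-12 cells (Rattus norvegicus) for cytotoxicity, read by WST assay, with a stated time of 24 h; a lower number here means that less compound is tolerated, a higher number that more compound is tolerated. Compound 3 stands clearly apart from only one of the other two. There is a 3.3-fold higher number from compound 1 to compound 3 (0.52 log units; beyond the scatter), while there is only a 1.4-fold higher number from compound 2 to compound 3 (0.13 log units; within the scatter), so compound 2 and compound 3 cannot be told apart.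

The next compound, compound 4 `O=C(/C=C/c1cc(O)ccc1O)CC(=O)/C=C/c1cc(O)ccc1O`, differs from compound 3 by one change: 2,5-dihydroxyphenyl in place of 2,3-dihydroxyphenyl on a double-bonded chain carbon bound to a double-bonded chain carbon. The closest guide is the same swap of groups, seen once already: a 1.4-fold higher number from compound 2 to compound 3 (0.13 log units; within the scatter). Two other steps replace a different group, 3,4-dihydroxyphenyl: a 2.4-fold higher number from compound 1 to compound 2 (0.39 log units; beyond the scatter) and a 3.3-fold higher number from compound 1 to compound 3 (0.52 log units; beyond the scatter). Both are modest, and they say less about this swap. One earlier example is thin evidence, but it gives no reason to expect a change beyond the scatter in this assay, at most a slight rise. The expected result is a 1.1-fold higher number from compound 3 to compound 4 (0.05 log units; within the scatter). For compound 4 the estimated value is 60000 nM, with an expected range from 30000 nM to 120000 nM.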

Compound 4, half-maximal cytotoxic concentration: 24000 nM
For compound 4 the middle estimate is 2.5-fold (0.40 log units) above the measured one; measured number below the stated range.
By their numbers in this assay, from the lowest: compounds 1, 4, 2 and 3 (each within the scatter of the next, the first and the last beyond it).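

In this assay, the swap of 2,3-dihydroxyphenyl for 2,5-dihydroxyphenyl now gives a 2.2-fold lower number from compound 3 to compound 4 (0.34 log units; beyond the scatter), whereas the same swap at the other end of the molecule gave a 1.4-fold higher number from compound 2 to compound 3 (0.13 log units; within the scatter). The two swaps differ in what stands at the far end of the chain: 2,3-dihydroxyphenyl in the earlier pair and 2,5-dihydroxyphenyl in the later one, so on these two examples the swap has no single fixed effect on tolerance, and its outcome seems to depend on the partner group. Nothing available here explains this difference. Still open, going by these compounds, is how the swap behaves with 3,4-dihydroxyphenyl as the partner group. Also open, on these data alone, is what happens with a methoxy group or an amine on the rings in place of a hydroxyl group, or with a longer chain joining them.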